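The compounds below may be only part of what the source reports. "The series", "measured", "known", "first", "only" and "open" are said of these compounds alone.

Working notes on the series, read in a functional assay on NCI-H460 cells (Homo sapiens) for antiproliferative activity, read by MTT assay, with a stated time of 48 h; on this read-out higher numbers stand for weaker inhibition and lower numbers for stronger inhibition. Compound 1 `CCCCCCC1(O)C(=O)Nc2ccc(Nc3ccc(OC)cc3)cc21` gives > 100000 nM, which is a limit of the assay and not a number. Compound 2 `CCCCCCC1(O)C(=O)Nc2ccc(Nc3ccc(F)cc3)cc21` gives 50700 nM. Compound 3 `CCCCCC1(O)C(=O)Nc2ccc(Nc3ccc(C(F)(F)F)cc3)cc21` gives 16300 nM, the lowest of the numbers shown, and compound 2 is its nearest neighbour, with the gap between them beyond the scatter.

Compound 4 `CCCCCCC1(O)C(=O)Nc2ccc(Nc3ccc(C(F)(F)F)cc3)cc21` is still unmeasured and differs from compound 3 by methyl in place of hydrogen on a saturated chain carbon, five bonds along the chain from a saturated ring carbon. Within the data shown here, the only measured step is an at least 1.9-fold lower number from compound 1 to compound 2 (0.29 log units; that floor lies within the scatter), which is fluoro in place of methoxy on an aromatic carbon and leaves the chain untouched. Among the measured compounds shown here, no measured step changes the chain alone, so it gives no direct guide, and no step beyond the scatter is expected in this assay. For compound 4 the expected value is 15000 nM, with an estimated range of 6000 nM to 40000 nM. This estimate means an expected 1.1-fold lower number from compound 3 to compound 4 (0.04 log units; within the scatter).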

Compound 4, half-maximal inhibitory concentration: 18800 nM
The estimate for compound 4 lay 1.3-fold (0.10 log units) below the measured number, within the range that was stated.
By their numbers in this assay, from the lowest: compounds 3 and 4 (each within the scatter of the next); then compound 2. At a limit, above all of these: compound 1.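

Among these compounds, the added methyl on the saturated chain carbon, five bonds along the chain from a saturated ring carbon, provides the first step that changes the chain alone: in this assay there is a 1.2-fold higher number from compound 3 to compound 4 (0.06 log units; within the scatter), so this extension does not separate the two compounds. Trifluoromethyl in place of fluoro on an aromatic carbon gives a 2.7-fold lower number from compound 2 to compound 4 (0.43 log units; beyond the scatter), which shows that, with the chain held constant, the aromatic group can shift the number beyond the scatter. Swapping the methoxy for trifluoromethyl gives an at least 5.3-fold lower number from compound 1 to compound 4 (0.72 log units; beyond the scatter), a floor only, set by a limit of the assay: the limit of > 100000 nM in this assay, at which 1 of the 4 values shown sits.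

From the compounds shown here alone, whether a longer chain, such as octyl, or a chain ending in an amine would behave the same way remains open. Also open, going by these compounds, are a nitrile or a carboxylic acid in place of trifluoromethyl, and whether the chain step would read the same with fluoro or methoxy on the aromatic carbon.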